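The compounds below may be only part of what the source reports. "The series", "measured", "known", "first", "only" and "open" are said of these compounds alone.

Measured in a functional assay on MCF7 cells (Homo sapiens) for antiproliferative activity; a lower number here means a stronger inhibitor, a higher number a weaker inhibitor:
- compound 1 `COc1ccc(C(=O)Nc2cc3ccc(OC4CCN(C)CC4)c(C)c3oc2=O)cc1CC=C(C)C`: 1580 nM
- compound 2 `Cc1c(OC2CCN(C)CC2)ccc2cc(NC(=O)c3ccc(O)c(CCC(C)C)c3)c(=O)oc12`: 1250 nM
- compound 3 `C=CCc1cc(C(=O)Nc2cc3ccc(OC4CCN(C)CC4)c(C)c3oc2=O)ccc1OC(C)=O`: 2000 nM

Compound 1 sits in the middle of these three numbers, within the usual scatter of both compound 2 and compound 3. Compound 4 `CC(C)=CCc1cc(C(=O)Nc2cc3ccc(OC4CCN(C)CC4)c(C)c3oc2=O)ccc1OC1CCN(C)CC1` differs from compound 1 in one place, with 1-methylpiperidin-4-yl in place of methyl on an oxygen on an aromatic ring. For the measured compounds named here, no measured pair shows this change directly, so any expectation is uncertain. Compound 2 at 1250 nM and compound 3 at 2000 nM differ from compound 1 in more than one place, yet stay within the scatter of it. A step beyond the scatter in this assay is therefore not expected, in either direction. The estimated change is a 1.0-fold higher number from compound 1 to compound 4 (0.01 log units; within the scatter). For compound 4 the expected value is 1600 nM, with an estimated range of 600 nM to 4500 nM.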

Compound 4, half-maximal inhibitory concentration: 470 nM
The estimate for compound 4 lay 3.4-fold (0.53 log units) above the measured number; measured number below the stated range.
By their numbers in this assay, from the lowest: compound 4; then compounds 2, 1 and 3 (each within the scatter of the next).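

In this assay, for the compounds shown here, the step of a 3.4-fold lower number from compound 1 to compound 4 (0.53 log units; beyond the scatter) is the first change here that lies beyond the scatter, with methoxy becoming (1-methylpiperidin-4-yl)oxy. It shows that activity responds to the group on this oxygen on an aromatic ring, and that a far larger group, with a six-membered ring and a nitrogen, is accepted there with a gain rather than a loss. Nothing measured here explains this gain.

As far as these compounds go, it remains open whether the ring or its nitrogen matters more. A cyclohexyl group or an open dimethylaminoethyl chain on this oxygen could separate the two.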